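Hydroxymethoxybenzyl in place of fluoromethoxybenzyl on an aryl ether

This account rests on a few compounds, and the source may have more. Where it says the series, first, only, none or still open, it means among the compounds named here.

Measured so far in a physicochemical assay for acid dissociation:
compound 1 `COc1ccc(-c2ccc3c(NCCCNCc4cccc(OC)c4O)ccnc3c2)cc1`: 9.47
compound 2 `COc1ccc(Oc2ccc3c(NCCCNCc4cc(F)ccc4OC)ccnc3c2)cc1`: 9.28
compound 3 `COc1ccc(F)cc1CNCCCNc1ccnc2cc(Oc3cccc(N(C)C)c3)ccc12`: 9.28

Compound 2 stands level with compound 3 at the digits shown, the two together the lowest of the three numbers, while compound 1 sits a little higher, a gap that stays within the scatter. Going by the values given here, the only step between measured compounds that differ in a single place, no change at the digits printed from compound 2 to compound 3 (within the scatter), shows that swapping one aryl group for another on the ether oxygen leaves this assay untouched.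

Compound 4 `COc1ccc(Oc2ccc3c(NCCCNCc4cccc(OC)c4O)ccnc3c2)cc1` arises from compound 2 by 2-hydroxy-3-methoxyphenyl in place of 5-fluoro-2-methoxyphenyl on a saturated chain carbon bound to an amine nitrogen. Among the compounds with values here, no measured pair isolates this exact exchange. The nearest evidence is compound 1, which carries the same 2-hydroxy-3-methoxybenzyl group but also differs from compound 2 in a second place; in this assay compound 1 gives 9.47, and compound 2 gives 9.28, a difference within the scatter. Within the data shown here, the one measured step concerns the far end of the molecule and says nothing direct about the benzyl group. Compound 4 is therefore expected to land close to compound 2, with an expected step of a number 0.12 log units higher from compound 2 to compound 4 (within the scatter) that stays within the scatter. Compound 4 is estimated at 9.4, with a range from 9.05 to 9.75.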

Compound 4, acid dissociation constant: 9.28
For compound 4 the middle estimate is 0.12 log units above the measured one; the measured number falls inside the stated range.
By their numbers in this assay, from the lowest: compounds 2, 3, 4 and 1 (each within the scatter of the next).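

In this assay, the exchange on the saturated chain carbon bound to an amine nitrogen can now be read on its own: 2-hydroxy-3-methoxyphenyl, with 1 hydrogen-bond donor, in place of 5-fluoro-2-methoxyphenyl, with 0 hydrogen-bond donors, gives no change at the digits printed from compound 2 to compound 4 (within the scatter), so this position tolerates the change without a step beyond the scatter. Compound 1 and compound 2 differ in two places. Compound 4 supplies the single-place comparison that those two could not give: 4-methoxyphenoxy in place of 4-methoxyphenyl on an aromatic carbon gives a number 0.19 log units lower from compound 1 to compound 4 (within the scatter), so this exchange too stays within the scatter, as does each of the other single-place steps shown. Nothing in the material at hand explains why these numbers stay so close.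

On these data alone, it remains open whether a carboxylic acid on the benzyl ring, or a piperidine in place of the (2-hydroxy-3-methoxybenzyl)amino group, would shift the number beyond the scatter. A longer chain carrying the same amine nitrogen is an equally open question, and the compounds shown do not tell which proton the number reports.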